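Thiourea cytotoxicity on Vero cells: aryl gives way to acetyl

The source may hold more compounds than are shown below. What is called first, only, known or untested is meant among the compounds shown, and "the series" means these compounds.

Among the compounds with values here, in an ADME assay on Vero 76 cells (Chlorocebus sabaeus) for cytotoxicity, read by crystal violet staining, with a stated time of 96 h (a higher number here means that more compound is tolerated, a lower number that less compound is tolerated), compound 1 `Fc1ccccc1NC(=S)Nc1cccc(C(F)(F)F)c1` gives 64000 nM, the highest of the three numbers measured so far. Compound 3 `Cc1ccc(NC(=S)Nc2cccc(C(F)(F)F)c2)cc1Cl` gives 20000 nM, and compound 2 `CC[C@H]1CC[C@H](c2ccc(NC(=S)Nc3cccc(C(F)(F)F)c3)cc2)CC1` gives 10000 nM; both of these stand beyond the scatter below compound 1. Compound 4 `CC(=O)NC(=S)Nc1cccc(C(F)(F)F)c1` has not yet been measured in this assay. It differs from compound 1 in one place: acetyl in place of 2-fluorophenyl on an amide-type nitrogen. Within the data shown here, no measured pair of this kind exists, so the size of the step is uncertain, but the three numbers put the smallest substituent at the highest value, with compound 2 carrying the largest and sitting lowest. Compound 4 is therefore expected to be tolerated at least as well as compound 1, with an estimated step of a 1.6-fold higher number from compound 1 to compound 4 (0.19 log units; within the scatter). The estimate for compound 4 is 100000 nM, with a range from 35000 nM to 300000 nM.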

Compound 4, half-maximal cytotoxic concentration: > 100000 nM
Compound 4: only a limit was reported (the forecaster's own chance of this, stated with the estimate: 30%); the middle value lies on the limit itself.
By their numbers in this assay, from the lowest: compounds 2 and 3 (each within the scatter of the next); then compound 1. At a limit, above all of these: compound 4.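

In this assay, compounds 1, 2 and 3 all carry an aryl group on this nitrogen, and compound 4 shows that the position also accepts acetyl, a group with no ring, with an at least 1.5-fold higher number from compound 1 to compound 4 (0.19 log units; that floor lies within the scatter). That floor does not by itself separate the two compounds. For compound 4, > 100000 nM is a limit of the assay and not a number, so the true size of the step cannot be read: the limit of > 100000 nM in this assay, at which 1 of the 4 values shown sits.

Open, from the compounds shown here alone, is how a longer acyl chain, such as butanoyl, or a simple alkyl chain would fare on this nitrogen. Going by these compounds, an amine or a carboxylic acid carried on such a chain is equally open.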